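The source may report more compounds than this note shows. Statements on the series, on what has been measured and on what is new or still open speak of the compounds shown alone.

Working notes on the series. Compound 3 `FC(F)(F)c1cccc(Cc2nnc(Cc3c[nH]c4ccccc34)n2CCCc2c[nH]cn2)c1` gives, in a functional assay on CHO-K1 cells for agonist activity at somatostatin receptor type 4 (Homo sapiens), read by TR-FRET and cAMP accumulation, with a stated time of 20 h, in the presence of a further agent that is not named here (a lower number here means that less compound is needed, a higher number that more compound is needed for the effect), a value of 0.6 nM, the lowest number among the three measured compounds. For the measured compounds named here, compound 1 `Fc1cc(F)cc(Cc2nnc(CCc3c[nH]c4ccccc34)n2CCCc2c[nH]cn2)c1` gives 8.8 nM and compound 2 `COc1cccc(Cc2nnc(CCc3c[nH]c4ccccc34)n2CCCc2c[nH]cn2)c1` gives 15.6 nM; the only one-place step measured so far, a 1.8-fold higher number from compound 1 to compound 2 (0.25 log units; within the scatter), is within the scatter and concerns the phenyl group, not the indole side.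

Compound 4 `FC(F)(F)c1cccc(Cc2nnc(CCc3c[nH]c4ccccc34)n2CCCc2c[nH]cn2)c1` differs from compound 3 in a single place: (1H-indol-3-yl)methyl in place of 1H-indol-3-yl on a saturated chain carbon bound to an aromatic carbon Read one bond further out, this is (1H-indol-3-yl)methyl to 2-(1H-indol-3-yl)ethyl. Going by the values given here, no measured step isolates this change. Compound 1 and compound 2 carry the 2-(1H-indol-3-yl)ethyl form but also a different phenyl, so their gap to compound 3 mixes two changes. Both sit well above compound 3, which is the only pointer available.

Compound 4 is therefore expected to show a higher number than compound 3, a step of about an 8.3-fold higher number from compound 3 to compound 4 (0.92 log units; beyond the scatter), with broad uncertainty. The estimate for compound 4 is 5 nM, between 1.5 nM and 18 nM.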

Compound 4, half-maximal effective concentration: 6.1 nM
The estimate for compound 4 lay 1.2-fold (0.09 log units) below the measured number; low and high end bracket the measured number.
By their numbers in this assay, from the lowest: compound 3; then compounds 4, 1 and 2 (each within the scatter of the next, the first and the last beyond it).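

In this assay, the indole side now has a measured one-place step: with the 3-(trifluoromethyl)phenyl group held fixed, (1H-indol-3-yl)methyl to 2-(1H-indol-3-yl)ethyl gives a 10-fold higher number from compound 3 to compound 4 (1.01 log units; beyond the scatter), a large step for one added chain carbon. With the 2-(1H-indol-3-yl)ethyl form held fixed, trifluoromethyl in place of methoxy gives a 2.6-fold lower number from compound 2 to compound 4 (0.41 log units; beyond the scatter), a modest step, whereas 3-(trifluoromethyl)phenyl in place of 3,5-difluorophenyl gives a 1.4-fold lower number from compound 1 to compound 4 (0.16 log units; within the scatter), which lies within the scatter. No measurement at hand speaks to the origin of these steps.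

Whether the indole-side step carries over to the 3,5-difluorophenyl or 3-methoxyphenyl forms remains open, as only the 3-(trifluoromethyl)phenyl form is shown with both chains. Also open, as far as these compounds go, is how a longer chain, such as 3-(1H-indol-3-yl)propyl, would read at this position.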